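This account rests on a few compounds, and the source may have more. Where it says the series, first, only, none or still open, it means among the compounds named here.

Series notes. Two compounds have been run so far in a functional assay on THP-1 cells (Homo sapiens) for inhibition, read by sulforhodamine B assay, tested at 100 uM; on this read-out higher numbers stand for more inhibition of growth at the one concentration tested and lower numbers for less inhibition of growth. Compound 1 `COc1cc(C2CC(c3ccc(OCc4cn(Cc5ccc([N+](=O)[O-])cc5)nn4)cc3)=NN2C(C)=O)ccc1Oc1cn(Cc2ccc([N+](=O)[O-])cc2)nn1` carries two nitrobenzyl-triazole arms on the shared core; in this assay compound 1 gives 15%. Compound 2 `COc1cc(C2CC(c3ccc([N+](=O)[O-])cc3)=NN2C(C)=O)ccc1OCc1cn(Cc2ccc([N+](=O)[O-])cc2)nn1` keeps one such arm and bears a 4-nitrophenyl on the carbon with a double bond to nitrogen; in this assay compound 2 gives 59%. Compound 2 thus stands highest of the two numbers, and compound 1 sits below it by a gap beyond the usual scatter. Going by the values given here, because the two compounds differ in more than one place, no single-point step can be drawn between them.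

Compound 3 `COc1cc(C2CC(c3cccc4ccccc34)=NN2C(C)=O)ccc1OCc1cn(Cc2ccc([N+](=O)[O-])cc2)nn1` is the next entry and remains to be measured. Relative to compound 2 the change is naphthalen-1-yl in place of 4-nitrophenyl on a carbon with a double bond to nitrogen. Nothing measured in this series isolates this position, so the expectation rests only on the spread of the two known values. A step of moderate size downward is expected, a number 14 percentage points lower from compound 2 to compound 3 (beyond the scatter), possibly no larger than the scatter. Compound 3 is therefore estimated at 45%, within a range from 15% to 75%.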

Compound 3, percent growth inhibition at one concentration: 79%
Compound 3: middle estimate off by 34 percentage points, on the low side, and the stated range ends below it.
By their numbers in this assay, from the lowest: compound 1; then compound 2; then compound 3.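

In this assay, going by these compounds alone, naphthalen-1-yl in place of 4-nitrophenyl on the carbon with a double bond to nitrogen gives a number 20 percentage points higher from compound 2 to compound 3 (beyond the scatter), the first step that isolates a single position. At this position, growth inhibition does not depend on keeping the 4-nitrophenyl: the entering group has no hydrogen-bond acceptors where the leaving group has 2, and it has 2 six-membered aromatic rings of carbon only where the leaving group has one, yet the number rises. There is no measured evidence on why the number rises.

The ring count and the acceptor count change together in this one step, so the compounds shown leave open which of the two goes with the rise, and a plain phenyl at the same position would help to separate them. Also open, from the compounds shown here alone, is how a phenyl carrying an amine or a carboxylic acid would read here, and whether the step holds beyond a single tested concentration, as one step on one pair gives no trend across this position.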